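The compounds below may be only part of what the source reports. "The series", "measured", "known", "first", "only" and "open" are said of these compounds alone.

Compound 3 `O=S(=O)(NCCCNCC1COc2ccccc2O1)c1cc(C(F)(F)F)cc(C(F)(F)F)c1` is one of three analogues built on a shared core that differs only in the group attached to a saturated chain carbon bound to an amine nitrogen. In a functional assay on MIA PaCa-2 cells (Homo sapiens) for inhibition, read by MTT assay, with a stated time of 72 h (a higher number here means a weaker inhibitor of growth, a lower number a stronger inhibitor of growth), compound 3 gives 2600 nM. Compound 1 `CC(C)(C)c1ccc(CNCCCNS(=O)(=O)c2cc(C(F)(F)F)cc(C(F)(F)F)c2)cc1` gives 2300 nM in this assay, and compound 2 `O=S(=O)(NCCCNCc1ccc(Cl)c(Cl)c1)c1cc(C(F)(F)F)cc(C(F)(F)F)c1` gives 2700 nM. The steps of a 1.2-fold higher number from compound 1 to compound 2 (0.07 log units; within the scatter), a 1.1-fold higher number from compound 1 to compound 3 (0.05 log units; within the scatter) and a 1.0-fold lower number from compound 2 to compound 3 (0.02 log units; within the scatter) all lie within the scatter, so compound 3 cannot be set apart from either of its neighbours on these numbers.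

Compound 4 `O=S(=O)(NCCCNCc1ccccc1)c1cc(C(F)(F)F)cc(C(F)(F)F)c1` differs from compound 3 in one place: phenyl in place of 2,3-dihydro-1,4-benzodioxin-2-yl on a saturated chain carbon bound to an amine nitrogen. Within the data shown here, no measured pair shows exactly this exchange, but all three measured steps bear on it, since each swapped the group at that same carbon among 4-(tert-butyl)phenyl, 3,4-dichlorophenyl and 2,3-dihydro-1,4-benzodioxin-2-yl without moving the number beyond the scatter. A plain phenyl at that position is therefore expected to give a step of a 1.2-fold higher number from compound 3 to compound 4 (0.06 log units; within the scatter) that stays within the scatter. Compound 4 is estimated at 3000 nM in this assay, with an expected range from 1500 nM to 6500 nM.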

Compound 4, concentration for 50% growth inhibition: 11000 nM
Beside the measured number, compound 4's estimate is 3.7-fold (0.56 log units) below it, and the stated range ends below it.
By their numbers in this assay, from the lowest: compounds 1, 3 and 2 (each within the scatter of the next); then compound 4.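

In this assay the group on the saturated chain carbon bound to an amine nitrogen proves not to be freely exchangeable, since plain phenyl stands apart from all three earlier groups, with a 4.2-fold higher number from compound 3 to compound 4 (0.63 log units; beyond the scatter) for the loss of the 2,3-dihydro-1,4-benzodioxin-2-yl group and a 4.1-fold higher number from compound 2 to compound 4 (0.61 log units; beyond the scatter) for the loss of the two chlorines. Hydrogen in place of tert-butyl on an aromatic carbon gives a 4.8-fold higher number from compound 1 to compound 4 (0.68 log units; beyond the scatter) as well, so among these four compounds the bare phenyl alone gives the weaker growth inhibition. Nothing shown here accounts for this gap.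

As far as these compounds go, whether a single chlorine, as in a 4-chlorophenyl group, or a methoxy group on the phenyl ring would be enough to close the gap remains open. So does the effect of replacing the phenyl with a pyridine ring.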